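Series notes: replacing the extended urea of compound 2

A few compounds are considered here, and "the series" means these few. Any claim that something is new, unique, unknown or untested is made for them only; others in the source may bear on it.

Compound 2 `COc1cc(NC(C)CCCNC(=O)NNC(=O)Nc2ccc(Br)cc2)c2ncccc2c1` gives 101000 nM in a functional assay on HeLa cells (Homo sapiens) for inhibition, read by MTT assay, with a stated time of 72 h (a higher number here means a weaker inhibitor, a lower number a stronger inhibitor), the weakest result of the three measured compounds. Compound 1 `COc1cc(NC(C)CCCNC(=O)Nc2ccc(F)cc2)c2ncccc2c1` gives 20000 nM, and compound 3 `COc1cc(NC(C)CCCNC(=O)Nc2cccc(O)c2)c2ncccc2c1` gives 48000 nM. Compound 4 `COc1cc(NC(C)CCCNC(=O)Nc2cccc(C(F)(F)F)c2)c2ncccc2c1` differs from compound 2 as follows: 3-(trifluoromethyl)phenyl in place of ((4-bromophenyl)carbamoyl)amino on an amide-type nitrogen. Within the data shown here, two measured steps bear on this change, since both remove or add the same leaving group: a 5.1-fold higher number from compound 1 to compound 2 (0.70 log units; beyond the scatter) and a 2.1-fold lower number from compound 2 to compound 3 (0.32 log units; beyond the scatter). Both point to a lower number when an aryl group sits directly on the amide-type nitrogen, with the size depending on the aryl ring. For compound 4 a step of about a 3.4-fold lower number from compound 2 to compound 4 (0.53 log units; beyond the scatter) is therefore expected, giving an estimate of 30000 nM with a range from 12000 nM to 75000 nM.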

Compound 4, half-maximal inhibitory concentration: 14000 nM
The estimate for compound 4 lay 2.1-fold (0.33 log units) above the measured number, and the stated range covers the measured number.
By their numbers in this assay, from the lowest: compounds 4 and 1 (each within the scatter of the next); then compound 3; then compound 2.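

In this assay, 3-(trifluoromethyl)phenyl in place of the extended urea gives a 7.2-fold lower number from compound 2 to compound 4 (0.86 log units; beyond the scatter), so this change on the amide-type nitrogen is tolerated with no loss. The aryl substituent also counts: trifluoromethyl in place of hydroxy on the aromatic carbon gives a 3.4-fold lower number from compound 3 to compound 4 (0.54 log units; beyond the scatter). Against 4-fluorophenyl the change gives a 1.4-fold lower number from compound 1 to compound 4 (0.15 log units; within the scatter), which sets no order between those two aryl groups. As far as these compounds go, how an amine or a carboxylic acid on the aryl ring would compare remains open. Nothing available explains these differences.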